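The source may hold more compounds than are shown below. What is called first, only, known or untested is meant among the compounds shown, and "the series" means these compounds.

In a functional assay on HepG2 cells (Homo sapiens) for antiproliferative activity, read by MTT assay, with a stated time of 72 h (on this read-out lower numbers stand for stronger inhibition and higher numbers for weaker inhibition), compound 3 `O=C1O[C@H]([C@@H](O)Cn2cc(CNS(=O)(=O)c3ccc(Cl)cc3)nn2)C(OCc2ccccc2)=C1OCc1ccccc1` gives 7510 nM. Among the compounds with values here, compound 1 `CCCCCc1ccc(-c2cn(C[C@H](O)[C@H]3OC(=O)C(OCc4ccccc4)=C3OCc3ccccc3)nn2)cc1` gives 7460 nM in this assay, so these two stand level, and they are the only exact numbers available. In this assay compound 2 `COc1ccc(-c2cn(C/C=C3\OC(=O)C(OCc4ccccc4)=C3OCc3ccccc3)nn2)cc1` reads > 100000 nM, which is a limit and not a number.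

The next structure is compound 4 `O=C1O[C@H]([C@@H](O)Cn2ccnn2)C(OCc2ccccc2)=C1OCc1ccccc1`, which loses a whole group from compound 3: hydrogen in place of (((4-chlorophenyl)sulfonyl)amino)methyl on an aromatic carbon. Hydrogen takes the place of (((4-chlorophenyl)sulfonyl)amino)methyl on an aromatic carbon of a five-membered aromatic ring with 3 nitrogen.

Within the data shown here, only one measured step bears on this change: a 1.0-fold higher number from compound 1 to compound 3 (0.00 log units; within the scatter). There, 4-pentylphenyl and the sulfonyl-bearing group, though very different in make-up, gave the same reading. Among the measured compounds shown here, that step compares two substantial groups, however, and no measured compound carries plain hydrogen at this spot, so it gives only a loose guide. Since both measured groups go with readings in the same range, removing the group altogether is expected to weaken inhibition rather than leave it unchanged. The expected size of the change is a 4.0-fold higher number from compound 3 to compound 4 (0.60 log units; beyond the scatter), and it remains uncertain. Compound 4 is estimated at 30000 nM, with an expected range from 8000 nM to 100000 nM.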

Compound 4, half-maximal inhibitory concentration: > 100000 nM
Compound 4 was reported as a limit (the forecaster's own chance of this, stated with the estimate: 30%); middle value at least 3.3-fold (0.52 log units) from the limit.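

The earlier step, a 1.0-fold higher number from compound 1 to compound 3 (0.00 log units; within the scatter), could have meant that this aromatic carbon of the five-membered aromatic ring with 3 nitrogen tolerates almost anything, since two very different groups gave level readings there. Hydrogen rules that out: with the group gone the steps are an at least 13-fold higher number from compound 3 to compound 4 (1.12 log units; beyond the scatter) and an at least 13-fold higher number from compound 1 to compound 4 (1.12 log units; beyond the scatter), so in this assay the shared core with plain hydrogen at this carbon gives no exact reading, while each of the two large groups does. The reading for compound 4 is a limit and not a number, so both steps give only the smallest possible size of the change, and the true loss may be greater: the limit of > 100000 nM in this assay, at which 2 of the 4 values shown sit.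

What remains open is how much of a group this carbon needs, since nothing shown lies between hydrogen and the two large groups. A methyl group, a plain phenyl ring or a short aminomethyl chain at this carbon would show whether a small group already restores a measurable reading, or whether the full size of the 4-pentylphenyl or (((4-chlorophenyl)sulfonyl)amino)methyl group is required.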